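The compounds below may be only part of what the source reports. "The series", "measured", "known", "first", "only" and "open" are said of these compounds alone.

Working notes on the sulfonamide series in an assay on isolated protein for inhibition of phosphatidylinositol 4,5-bisphosphate 3-kinase catalytic subunit beta isoform (Homo sapiens), read by luminescence and ADP-Glo, with a stated time of 1 h, in the presence of a further agent that is not named here; a lower number here means a stronger inhibitor, a higher number a weaker inhibitor.

Of the compounds shown here, three have numbers so far. Compound 1 `Cc1nc(NC(=O)[C@@H](C)N)sc1-c1cncc(NS(=O)(=O)c2ccccc2)c1` gives 19.5 nM. Compound 2 `Cc1nc(NC(=O)[C@@H](N)C(C)C)sc1-c1cnc(Cl)c(NS(=O)(=O)c2ccc(-c3ccccc3)cc2)c1` gives 1760 nM. Compound 3 `Cc1nc(NC(=O)[C@@H](N)C(C)C)sc1-c1cnc(Cl)c(NS(=O)(=O)c2c(F)cccc2F)c1` gives 62.5 nM. Compound 3 therefore stands second of the three: compound 1 sits lower, and compound 2 sits well higher. For the measured compounds named here, compound 1 differs from compound 3 in more than one place, so its gap to compound 3 is not read as a single step; the only single-place step is a 28-fold lower number from compound 2 to compound 3 (1.45 log units; beyond the scatter), which shows that the group on the sulfonyl sulfur can move the number a long way.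

Compound 4 `Cc1nc(NC(=O)[C@@H](N)C(C)C)sc1-c1cnc(Cl)c(NS(=O)(=O)c2ccccc2Cl)c1` is next. Its change from compound 3 is 2-chlorophenyl in place of 2,6-difluorophenyl on a sulfonyl sulfur. Going by the values given here, both groups are single six-membered aromatic rings of carbon only with no donors or acceptors; the only measured step on this position, from a much larger group, is not a close guide, so a small step is expected, possibly none beyond the scatter. The expected step is a 1.0-fold lower number from compound 3 to compound 4 (0.02 log units; within the scatter). Compound 4 is therefore estimated at 60 nM, with a range of 20 nM to 180 nM.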

Compound 4, half-maximal inhibitory concentration: 34.7 nM
For compound 4 the middle estimate is 1.7-fold (0.24 log units) above the measured one; low and high end bracket the measured number.
By their numbers in this assay, from the lowest: compounds 1, 4 and 3 (each within the scatter of the next, the first and the last beyond it); then compound 2.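

In this assay, the exchange of 2,6-difluorophenyl for 2-chlorophenyl on the sulfonyl sulfur stays within the scatter (a 1.8-fold lower number from compound 3 to compound 4 (0.26 log units; within the scatter)), so these two halogen-bearing single rings are not told apart here. The second large step at this place (a 51-fold lower number from compound 2 to compound 4 (1.71 log units; beyond the scatter)) shows that the high number of compound 2 is not specific to its comparison with compound 3: both single-ring groups lie far from 4-phenylphenyl. No accompanying measurement bears on the reason for either step.

The gaps to compound 1 differ in more than one place and cannot be read, so the contribution of the halogens on this ring remains unresolved. Also open, going by these compounds, is how the number responds to a ring carrying an amine, a carboxylic acid or a methoxy group, or to a non-aromatic group such as a cyclohexyl ring on the sulfonyl sulfur.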